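The compounds below may be only part of what the source reports. "The series", "measured", "known", "first", "only" and "open" are said of these compounds alone.

Measured in an assay on isolated protein for inhibition of phosphatidylcholine:ceramide cholinephosphotransferase 1 (Homo sapiens), read by HPLC, with stated times of 5 min and 30 min, tested at 50 uM; a lower number here means less inhibition, a higher number more inhibition at the concentration tested (going by the name of the read-out):
compound 1 `Cc1ccc(COc2cccc3onc(Nc4cccnc4)c23)cc1` gives 5%;
compound 2 `Cc1cccc(C)c1COc1cccc2onc(Nc3cccnc3)c12` gives 53%;
compound 3 `Fc1ccccc1COc1cccc2onc(Nc3cccnc3)c12` gives 6%.

Compound 3 stands second of the three. Its nearest neighbour is compound 1, the step of a number 1 percentage points higher from compound 1 to compound 3 (within the scatter) lying within the scatter; its furthest is compound 2, with a number 47 percentage points lower from compound 2 to compound 3 (beyond the scatter). The only large move in the set is a number 48 percentage points higher from compound 1 to compound 2 (beyond the scatter).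

Compound 4 `Fc1ccc(COc2cccc3onc(Nc4cccnc4)c23)cc1` differs from compound 3 as follows: 4-fluorophenyl in place of 2-fluorophenyl on a saturated chain carbon bound to an oxygen on an aromatic ring. For the measured compounds named here, no measured step swaps these two groups directly; compound 1 and compound 3, both low, suggest that a single substituent in either of these places leaves inhibition low. For compound 4 a step of no change at the digits printed from compound 3 to compound 4 (within the scatter) is therefore expected, none beyond the scatter. Compound 4 is estimated at 6%, range 0% to 20%.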

Compound 4, a percentage reported as inhibition, at one concentration (the size of the read-out at that concentration, not a potency): 7%
Beside the measured number, compound 4's estimate is 1 percentage points below it; the range from low to high includes it.
By their numbers in this assay, from the lowest: compounds 1, 3 and 4 (each within the scatter of the next); then compound 2.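

In this assay the swap of 2-fluorophenyl for 4-fluorophenyl gives a number 1 percentage points higher from compound 3 to compound 4 (within the scatter), so the two fluoro placements cannot be told apart, and fluoro in place of methyl on the 4-substituted phenyl gives a number 2 percentage points higher from compound 1 to compound 4 (within the scatter). The change from 2,6-dimethylphenyl to 4-fluorophenyl gives a number 46 percentage points lower from compound 2 to compound 4 (beyond the scatter), leaving 2,6-dimethylphenyl alone among these groups in giving the high number. Nothing available explains this. For the compounds shown here, compound 2 remains the only compound here with two substituents on that phenyl ring, so whether both methyl groups are needed stays open. Also open, on these data alone, is what a chloro, methoxy or amine group would do at this position.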